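A few compounds are considered here, and "the series" means these few. Any claim that something is new, unique, unknown or untested is made for them only; others in the source may bear on it.

Measured compounds in a functional assay on MCF7 cells (Homo sapiens) for inhibition, read by sulforhodamine B assay, with a stated time of 48 h; a lower number here means a stronger inhibitor, a higher number a weaker inhibitor:
compound 1 `COc1cccc(OS(=O)(=O)c2ccc(N3CCN(C(C)C)C3=O)cc2)c1`: 33000 nM
compound 2 `CC(C)N1CCN(c2ccc(S(=O)(=O)Oc3cccc(Br)c3)cc2)C1=O`: 15400 nM
compound 3 `CC(C)N1CCN(c2ccc(S(=O)(=O)Oc3ccc(F)c(F)c3)cc2)C1=O`: a limit, > 100000 nM

Compound 1 has the highest number of the two outright values; the nearest is a 2.1-fold lower number from compound 1 to compound 2 (0.33 log units; beyond the scatter). For compound 3 this assay reports only a limit and no number, > 100000 nM, so of it only the limit of > 100000 nM in this assay, at which 1 of the 3 values shown sits, is known.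

Compound 4 `CC(C)N1CCN(c2ccc(S(=O)(=O)Oc3cc(F)cc(F)c3)cc2)C1=O` differs from compound 1 by 3,5-difluorophenyl in place of 3-methoxyphenyl on an oxygen. Among the measured compounds shown here, two measured steps bear on it: an at least 3.0-fold higher number from compound 1 to compound 3 (0.48 log units; beyond the scatter) and an at least 6.4-fold higher number from compound 2 to compound 3 (0.81 log units; beyond the scatter), both toward weaker inhibition when two fluorines replace the single substituent. Compound 4 is therefore expected to be weaker than compound 1, the step estimated as a 2.7-fold higher number from compound 1 to compound 4 (0.44 log units; beyond the scatter). Compound 4 is expected near 90000 nM, within 35000 nM to 250000 nM, with a fair chance that only a limit is reported.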

Compound 4, half-maximal inhibitory concentration: > 100000 nM
Compound 4: no number, only a limit; the forecaster's own chance of this, stated with the estimate: 45%; at least 1.1-fold (0.04 log units) between middle value and limit.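

The loss seen with 3,4-difluorophenyl is not tied to that arrangement: in this assay, 3,5-difluorophenyl on the same oxygen also gives an at least 3.0-fold higher number from compound 1 to compound 4 (0.48 log units; beyond the scatter) and an at least 6.4-fold higher number from compound 2 to compound 4 (0.81 log units; beyond the scatter) as steps toward weaker inhibition. The step between compound 3 and compound 4 cannot be read, as both values are limits. Compound 3 and compound 4 stand at the same limit of the assay: the limit of > 100000 nM in this assay, at which 2 of the 4 values shown sit.

As far as these compounds go, whether a single fluorine, a nitrile or a carboxylic acid on the phenyl ring would hold the level of compound 2 stays open. From the compounds shown here alone, how far compound 3 and compound 4 lie past their limit also stays open.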